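From chloro to ethoxy: an expected step

The compounds below may be only part of what the source reports. "The series", "measured", "known", "first", "only" and "open" are said of these compounds alone.

compound 1 `C=C(Br)C(=O)Nc1ccc(/C=C/C(=O)c2ccc(F)cc2)cc1` gives 660 nM
compound 2 `C=C(Br)C(=O)Nc1ccc(/C=C/C(=O)c2ccc(Cl)cc2)cc1` gives 810 nM
compound 3 `C=C(Br)C(=O)Nc1ccc(/C=C/C(=O)c2cc(OC)c(OC)c(OC)c2)cc1` gives 850 nM

In a functional assay on MOLT-4 cells (Homo sapiens) for antiproliferative activity, with a stated time of 48 h (a lower number here means a stronger inhibitor, a higher number a weaker inhibitor), compound 2 gives 810 nM and sits within the scatter of both compound 1 and compound 3. Compound 4 `C=C(Br)C(=O)Nc1ccc(/C=C/C(=O)c2ccc(OCC)cc2)cc1` differs from compound 2 by ethoxy in place of chloro on an aromatic carbon para to a large group. Going by the values given here, the one measured step at that carbon is a 1.2-fold higher number from compound 1 to compound 2 (0.09 log units; within the scatter) and lies within the scatter, though it only exchanges one halogen for another. Compound 3, which carries methoxy groups on that ring, gives 850 nM and stays close to compound 2. Among the compounds with values here, no ethoxy compound has been measured, so the expectation is loose. The expected step of a 1.1-fold lower number from compound 2 to compound 4 (0.03 log units; within the scatter) stays within the scatter, with no direction favoured. The estimate for compound 4 is 750 nM with an expected range from 320 nM to 1700 nM in this assay as the likely outcome.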

Compound 4, half-maximal inhibitory concentration: 610 nM
Compound 4: the middle estimate sits 1.2-fold (0.09 log units) above what was measured; low and high end bracket the measured number.
By their numbers in this assay, from the lowest: compounds 4, 1, 2 and 3 (each within the scatter of the next).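

In this assay the exchange of chloro for ethoxy on this aromatic carbon gives a 1.3-fold lower number from compound 2 to compound 4 (0.12 log units; within the scatter) and the exchange of fluoro for ethoxy gives a 1.1-fold lower number from compound 1 to compound 4 (0.03 log units; within the scatter). This position therefore takes ethoxy, with 3 heavy atoms against 1 for chloro and an oxygen that the halogens lack, with no change beyond the scatter, which the halogen exchange alone could not show. No measurement available here accounts for this result.

Going by these compounds, whether an amine, a carboxylic acid or a chain longer than ethoxy on this carbon would also stay within the scatter remains open.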